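The compounds below may be only part of what the source reports. "The series", "measured", "known", "first", "only" and "open" are said of these compounds alone.

Working notes on the series.

Three compounds share one core. Compound 1 `CN(C)C(=S)N/N=C/c1ccc2ccccc2n1` carries a dimethyl group on the terminal nitrogen and gives 90 nM in a functional assay on HeLa cells (Homo sapiens) for antiproliferative activity, read by sulforhodamine B assay, with a stated time of 72 h; on this read-out higher numbers stand for weaker inhibition and lower numbers for stronger inhibition. Compound 2 `N#Cc1ccc(NC(=S)N/N=C/c2ccc3ccccc3n2)cc1` carries 4-cyanophenyl there and gives 20000 nM. Compound 3 `S=C(NCc1ccccc1)N/N=C/c1ccc2ccccc2n1` carries benzyl there and gives 62800 nM, the highest number of the three: compound 2 sits nearest, and compound 1 lies furthest away. Among the measured compounds shown here, the only single-point step recorded so far, a 3.1-fold higher number from compound 2 to compound 3 (0.50 log units; beyond the scatter), is a modest one.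

The next compound, compound 4 `NC(=S)N/N=C/c1ccc2ccccc2n1`, differs from compound 3 by hydrogen in place of benzyl on an amide-type nitrogen. For the measured compounds named here, no measured step removes a whole substituent from this nitrogen; the recorded step only swaps one aryl-type group for another, so it bears on the move only loosely. The wide spread between compound 1 and the two arylated analogues suggests that what sits on this nitrogen matters greatly, and a bare nitrogen may land between them.

Compound 4 is therefore expected to give about 8000 nM in this assay, within roughly 1500 nM to 40000 nM, which would mean an expected step of a 7.9-fold lower number from compound 3 to compound 4 (0.89 log units; beyond the scatter).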

Compound 4, half-maximal inhibitory concentration: 960 nM
Beside the measured number, compound 4's estimate is 8.3-fold (0.92 log units) above it; the measured number lies below the stated range.
By their numbers in this assay, from the lowest: compound 1; then compound 4; then compound 2; then compound 3.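

In this assay the bare nitrogen is now seen directly: hydrogen in place of benzyl gives a 65-fold lower number from compound 3 to compound 4 (1.82 log units; beyond the scatter) and hydrogen in place of 4-cyanophenyl gives a 21-fold lower number from compound 2 to compound 4 (1.32 log units; beyond the scatter), so both larger groups on this amide-type nitrogen go with far higher numbers than hydrogen. Substitution here does not raise the number in every case, and compound 1 goes against that pattern: amino in place of dimethylamino on the thiocarbonyl carbon gives an 11-fold higher number from compound 1 to compound 4 (1.03 log units; beyond the scatter), so the dimethylamino compound holds the lowest number of the series. No available evidence accounts for the size or direction of these steps.

From the compounds shown here alone, it remains open whether a single methyl or a longer chain such as propyl on this nitrogen follows compound 1 or compound 3. Also open, going by these compounds, is how a chain ending in an amine or a carboxylic acid would read here.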